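The compounds below may be only part of what the source reports. "The series", "measured", "known", "first", "only" and "open" are said of these compounds alone.

Going by the values given here, compound 1 `CC(C)c1cccc(C(C)C)c1NC(=O)Nc1ccccc1` is measured in an assay on isolated protein for inhibition of acyl-CoA:cholesterol acyltransferase (Oryctolagus cuniculus) (a higher number here means a weaker inhibitor, a lower number a stronger inhibitor), at 910 nM, the higher of the two numbers known so far. Compound 2 `CCCCc1ccc(NC(=O)Nc2c(C(C)C)cccc2C(C)C)cc1` gives 29 nM in this assay, and the step of a 31-fold lower number from compound 1 to compound 2 (1.50 log units; beyond the scatter) is large. Compound 3 `CCCCCCCCCCc1ccc(NC(=O)Nc2c(C(C)C)cccc2C(C)C)cc1` differs from compound 1 by decyl in place of hydrogen on an aromatic carbon. Among the compounds with values here, only the step to compound 2 bears on this change, and it was large in the lowering direction, so a similar-sized lowering step is expected here. The step expected from this is a 46-fold lower number from compound 1 to compound 3 (1.66 log units; beyond the scatter). For compound 3 the estimated value in this assay is 20 nM, with a range from 5 nM to 100 nM.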

Compound 3, half-maximal inhibitory concentration: 13 nM
For compound 3 the middle estimate is 1.5-fold (0.19 log units) above the measured one, within the range that was stated.
By their numbers in this assay, from the lowest: compound 3; then compound 2; then compound 1.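

In this assay, decyl on this aromatic carbon, para to a large group, keeps the large lowering already seen with butyl, giving a 70-fold lower number from compound 1 to compound 3 (1.85 log units; beyond the scatter) in all. Hexyl in place of hydrogen on the butyl chain adds only a 2.2-fold lower number from compound 2 to compound 3 (0.35 log units; beyond the scatter) here, so most of the lowering is already present in compound 2.

Still open, from the compounds shown here alone, are a longer chain than decyl and whether a chain ending in an amine or a carboxylic acid would keep the low number. No measured evidence explains the size of either step.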